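This account rests on a few compounds, and the source may have more. Where it says the series, first, only, none or still open, it means among the compounds named here.

Of the compounds shown here, three share one core and have been tested in an ADME assay on MT4 cells (Homo sapiens) for cytotoxicity, read by MTT assay; a higher number here means that more compound is tolerated, a lower number that less compound is tolerated. Compound 1 `CCOC(=O)/C(O)=C/C(=O)c1cn(Cc2cc(F)c(F)c(F)c2)c2cccc(OC)c12` gives 33400 nM. Within the data shown here, compound 2 `CCOC(=O)/C(O)=C/C(=O)c1cn(Cc2cccc(F)c2)c2cccc(OC)c12` gives 63200 nM; the step of a 1.9-fold higher number from compound 1 to compound 2 (0.28 log units; within the scatter) is the only one-place comparison among the measured compounds. Compound 3 `COc1cccc2c1c(C(=O)/C=C(\O)C(=O)O)cn2Cc1ccc(F)cc1F` gives 20800 nM. Compound 3 stands within the scatter of compound 1, while compound 2 stands beyond the scatter from compound 3, with compound 2 giving the higher number.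

Compound 4 `CCOC(=O)/C(O)=C/C(=O)c1cn(Cc2ccc(F)cc2F)c2cccc(OC)c12` has not yet been measured. It differs from compound 3 in one place: ethyl in place of hydrogen on an oxygen next to a carbonyl group. Among the measured compounds shown here, no measured step bears on this change; the one measured step concerns a different part of the molecule, and compounds 1 and 2 are the only other measured compounds carrying the ethoxycarbonyl group, with numbers in the same broad region as compound 3. On that basis, compound 4 is expected to show a step of about a 1.4-fold higher number from compound 3 to compound 4 (0.16 log units; within the scatter), not beyond the scatter. Compound 4 is therefore estimated at 30000 nM, with a range from 12000 nM to 75000 nM.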

Compound 4, half-maximal cytotoxic concentration: 65500 nM
Compound 4: the middle estimate sits 2.2-fold (0.34 log units) below what was measured, and the stated range covers the measured number.
By their numbers in this assay, from the lowest: compounds 3, 1, 2 and 4 (each within the scatter of the next, the first and the last beyond it).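

In this assay, among these compounds, this is the first measured change at this oxygen, and carboxy to ethoxycarbonyl gives a step beyond the scatter (a 3.1-fold higher number from compound 3 to compound 4 (0.50 log units; beyond the scatter)). With ethoxycarbonyl held in place, changing the fluorinated phenyl group gives steps that stay within the scatter: 2,4-difluorophenyl in place of 3-fluorophenyl (a 1.0-fold higher number from compound 2 to compound 4 (0.02 log units; within the scatter)) and 2,4-difluorophenyl in place of 3,4,5-trifluorophenyl (a 2.0-fold higher number from compound 1 to compound 4 (0.29 log units; within the scatter)). Among these comparisons involving compound 4, only ethyl in place of hydrogen gives a step beyond the scatter, and nothing available explains that step.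

From the compounds shown here alone, whether methyl or a longer chain on this oxygen would give a number like that of ethyl stays open. Going by these compounds, it also stays open whether ethyl in place of hydrogen gives a step of this size with 3-fluorophenyl or 3,4,5-trifluorophenyl.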